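The compounds below may be only part of what the source reports. "The series", "measured", "known", "first", "only" and "open" are said of these compounds alone.

For the measured compounds named here, in a physicochemical assay for solubility, read by LC-MS, in phosphate buffer, with a stated time of 24 h, at pH 7.4 (a lower number here means a less soluble compound, a higher number a more soluble compound), compound 1 `CN(c1ncco1)c1cnc(NCc2c(F)ccc3c2CCO3)n2cnnc12` gives 67000 nM and compound 2 `CC1(C)CC(=O)N(c2cnc(NCc3c(F)ccc4c3CCO4)n3cnnc23)C1` gives 57000 nM, so compound 2 stands within the scatter of the only other measured value. The next structure, compound 3 `CN(c1ccccc1)c1cnc(NCc2c(F)ccc3c2CCO3)n2cnnc12`, puts methyl(phenyl)amino in place of 4,4-dimethyl-2-oxopyrrolidin-1-yl on an aromatic carbon of the shared core: methyl(phenyl)amino in place of 4,4-dimethyl-2-oxopyrrolidin-1-yl on an aromatic carbon. Going by the values given here, only one measured step bears on this change. That step, a 1.2-fold lower number from compound 1 to compound 2 (0.07 log units; within the scatter), exchanged methyl(1,3-oxazol-2-yl)amino for the same 4,4-dimethyl-2-oxopyrrolidin-1-yl group and stayed within the scatter. It offers some reason to expect no large move, but neither measured compound has a six-membered aromatic ring of carbon only in this place, so the evidence is thin. A moderate drop in this assay is expected, with real uncertainty about its size, and the expected change is a 2.3-fold lower number from compound 2 to compound 3 (0.36 log units; beyond the scatter). The estimate for compound 3 is 25000 nM, with an expected range of 7000 nM to 60000 nM.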

Compound 3, solubility: < 2000 nM
Compound 3 was reported as a limit (the forecaster's own chance of this, stated with the estimate: 5%); middle value at least 12-fold (1.09 log units) from the limit.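

Compound 1 and compound 2 carry different groups on this aromatic carbon yet stay within the scatter of each other, so they gave no sign that the position could matter much in this assay. Compound 3 gives a limit, not a number: the limit of < 2000 nM in this assay, at which 1 of the 3 values shown sits. Even so, the change to methyl(phenyl)amino gives a large step, an at least 28-fold lower number from compound 2 to compound 3 (1.45 log units; beyond the scatter), and phenyl in place of 1,3-oxazol-2-yl on the nitrogen alone gives another, an at least 33-fold lower number from compound 1 to compound 3 (1.52 log units; beyond the scatter).

Going by these compounds, how far the true value of compound 3 lies past its limit stays open, so the full size of both steps is unknown. Also open, on these data alone, is whether a pyridine ring on that same nitrogen, or a phenyl ring carrying a carboxylic acid, would give a number closer to that of compound 1 or to that of compound 3.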